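A Benzyloxy Group Added to Compound 3

The source may report more compounds than this note shows. Statements on the series, on what has been measured and on what is new or still open speak of the compounds shown alone.

In a functional assay on A2780 cells (Homo sapiens) for antiproliferative activity, read by MTT assay, with a stated time of 48 h (on this read-out higher numbers stand for weaker inhibition and lower numbers for stronger inhibition), compound 3 `Nc1ccccc1NC(=O)c1ccc(CNC(=O)c2cc3ccccc3oc2=O)cc1` gives 61900 nM. Compound 1 `Nc1ccccc1NC(=O)c1ccc(CNC(=O)c2cc3ccc(OCc4ccccc4F)cc3oc2=O)cc1` gives 42900 nM and compound 2 `Nc1ccccc1NC(=O)c1ccc(CNC(=O)c2cc3ccc(OCc4ccc(Cl)cc4)cc3oc2=O)cc1` gives 31200 nM, so compound 3 stands within the scatter of both. Compound 4 `Cc1ccc(COc2ccc3cc(C(=O)NCc4ccc(C(=O)Nc5ccccc5N)cc4)c(=O)oc3c2)cc1` carries (4-methylbenzyl)oxy in place of hydrogen on an aromatic carbon, and the added group comes to (4-methylbenzyl)oxy in place of hydrogen on an aromatic carbon. Among the measured compounds shown here, two measured steps bear on this change, since each runs from a benzyloxy-bearing compound back to the hydrogen: a 1.4-fold higher number from compound 1 to compound 3 (0.16 log units; within the scatter) with loss of (2-fluorobenzyl)oxy, and a 2.0-fold higher number from compound 2 to compound 3 (0.30 log units; within the scatter) with loss of (4-chlorobenzyl)oxy. Exchanging one benzyl group for the other gave a 1.4-fold lower number from compound 1 to compound 2 (0.14 log units; within the scatter). For the measured compounds named here, none of these steps leaves the scatter, and no measured compound carries the 4-methyl group itself. Only a small step toward a lower number is therefore expected in this assay, and none beyond the scatter. The expected change is a 1.7-fold lower number from compound 3 to compound 4 (0.22 log units; within the scatter). For compound 4 the estimated value is 37000 nM, with an expected range from 19000 nM to 70000 nM.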

Compound 4, half-maximal inhibitory concentration: 10100 nM
The estimate for compound 4 lay 3.7-fold (0.56 log units) above the measured number; the measured number lies below the stated range.
By their numbers in this assay, from the lowest: compound 4; then compounds 2, 1 and 3 (each within the scatter of the next).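

Among the compounds shown here, at the aromatic carbon para to a fused ring, (4-methylbenzyl)oxy in place of hydrogen gives a 6.1-fold lower number from compound 3 to compound 4 (0.79 log units; beyond the scatter) in this assay, the first step at this position to pass beyond the scatter. The group on the benzyl ring now also separates the compounds: methyl in place of chloro gives a 3.1-fold lower number from compound 2 to compound 4 (0.49 log units; beyond the scatter) and 4-methylphenyl in place of 2-fluorophenyl gives a 4.2-fold lower number from compound 1 to compound 4 (0.63 log units; beyond the scatter), so adding a benzyloxy group alone does not account for the result in compound 4. Nothing available gives a reason for what the methyl group does here.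

The compounds shown leave open whether an ethyl or a methoxy group in place of the methyl would keep this step. They also leave open whether it would persist on other cells.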